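Changing the amide aryl group of compound 1

A few compounds are considered here, and "the series" means these few. Any claim that something is new, unique, unknown or untested is made for them only; others in the source may bear on it.

Compound 1 `COc1ccc(NC(=O)[C@H]2CCCN2C(=O)C2(c3cccc(Cl)c3)CCCC2)nc1`: 2 nM
Compound 2 `COc1ccc(NC(=O)[C@H]2CCCN2C(=O)C2(c3ccccc3)CCCC2)cc1`: 79.4 nM
Compound 3 `O=C(Nc1ccc2[nH]ncc2n1)[C@H]1CCCN1C(=O)C1(c2ccc(Cl)cc2)CC(F)(F)C1`: 0.316 nM

In an assay on isolated protein for inhibition of histone acetyltransferase p300 (Homo sapiens), with a stated time of 60 min (on this read-out higher numbers stand for weaker inhibition and lower numbers for stronger inhibition), compound 1 gives 2 nM, the second highest of the three numbers. Compound 3 gives 0.316 nM, a lower number beyond the scatter, while compound 2 gives 79.4 nM, a higher number well beyond it. Compound 4 `CNC(=O)c1ccc(NC(=O)[C@H]2CCCN2C(=O)C2(c3cccc(Cl)c3)CCCC2)cc1` has not yet been measured in this assay. It differs from compound 1 in one place: 4-(methylcarbamoyl)phenyl in place of 5-methoxypyridin-2-yl on an amide-type nitrogen. Among the compounds with values here, compound 2 and compound 3 each differ from compound 1 in more than one place, so no measured pair isolates this particular change, and no step between measured compounds can be drawn on. What the three values do show is that the group on the amide nitrogen moves the read-out over a wide span. The step from compound 1 to compound 4 is expected to be a moderate weakening, beyond the scatter, a 5.0-fold higher number from compound 1 to compound 4 (0.70 log units; beyond the scatter). Compound 4 is accordingly estimated at 10 nM, with a range from 2 nM to 60 nM.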

Compound 4, half-maximal inhibitory concentration in the histone acetyltransferase p300 assay: 0.794 nM
Estimate against measurement, compound 4: 13-fold (1.10 log units) above, and the stated range ends above it.
By their numbers in the histone acetyltransferase p300 assay, from the lowest: compound 3; then compound 4; then compound 1; then compound 2.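

Within the data shown here, in the histone acetyltransferase p300 assay, the single change of 5-methoxypyridin-2-yl to 4-(methylcarbamoyl)phenyl on the amide-type nitrogen gives a 2.5-fold lower number from compound 1 to compound 4 (0.40 log units; beyond the scatter), the first reading of this position with the rest of compound 1 held fixed. Here the larger group, which carries a hydrogen-bond donor absent from the group it replaces, is compatible with stronger inhibition. In a physicochemical assay for lipophilicity, at pH 7.4 (on this read-out higher numbers stand for higher lipophilicity and lower numbers for lower lipophilicity), compound 1 gives 6.8 and compound 4 gives 5.3. In this pair, that stronger inhibition is accompanied by a clear fall in the physicochemical assay: the measured distribution coefficient of compound 1, 6.8, and of compound 4, 5.3, a number 1.50 log units lower (beyond the scatter).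

The step swaps the ring and its substituent together, so the compounds shown cannot separate the effect of the ring nitrogen from that of the methylcarbamoyl group. Nor do they show whether a carboxylic acid, a primary carboxamide or a dimethylcarbamoyl group in the same place would follow compound 4.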